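Trifluorophenyl in place of a saturated ring: tolerance in cells

The source may hold more compounds than are shown below. What is called first, only, known or untested is meant among the compounds shown, and "the series" means these compounds.

Compound 1, `CC1CCCC(OCCCCCCN2C[C@H](O)[C@@H](O)[C@H](O)[C@H]2CO)C1C`, was measured in an ADME assay on MDBK cells (Bos taurus) for cytotoxicity, read by MTT assay; a lower number here means that less compound is tolerated, a higher number that more compound is tolerated. There compound 1 reaches only a limit of the assay, > 500000 nM. Compound 2, `OC[C@@H]1[C@@H](O)[C@H](O)[C@@H](O)CN1CCCCCCOc1c(F)c(F)c(F)c(F)c1F`, likewise gives only a limit in this assay, > 500000 nM. Compound 3, `OC[C@@H]1[C@@H](O)[C@H](O)[C@@H](O)CN1CCCc1ccc(OC2CCCCC2)cc1`, gives 295000 nM in this assay. Compound 1 thus stands among the compounds whose tolerated concentration is not pinned down by a number; (the limit of > 500000 nM in this assay, at which 2 of the 3 values shown sit).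

Compound 4, `OC[C@@H]1[C@@H](O)[C@H](O)[C@@H](O)CN1CCCCCCOc1c(F)cc(F)cc1F`, has not yet been measured. It differs from compound 1 in one place: a group of 9 heavy atoms (6 carbon, 3 fluorine; one six-membered aromatic ring of carbon only) in place of a group of 8 heavy atoms (8 carbon; one six-membered non-aromatic ring of carbon only), on an oxygen on a saturated carbon. Among the measured compounds shown here, no step between measured compounds carries this kind of change, so nothing can be compared directly. Compound 2, which also carries a fluorinated aromatic ring on that oxygen, is reported only as a limit, and compound 3, with a different ring, lies not far off. Compound 4 is therefore expected to stay near the limit of this assay, with a step of a number no higher from compound 1 to compound 4 (the limit leaves the size open) that is expected to lie within the scatter. For compound 4 the expected value is 500000 nM, estimated to fall between 250000 nM and 1000000 nM.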

Compound 4, half-maximal cytotoxic concentration: > 500000 nM
Compound 4: no number, only a limit (the forecaster's own chance of this, stated with the estimate: 70%); the middle value sits exactly at the limit.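

Compound 1 and compound 4 each give only a limit in this assay, and the step between them cannot be read. The compounds shown leave open how much of either is tolerated, and whether 2,4,6-trifluorophenyl in place of the non-aromatic ring changes that at all: the limit of > 500000 nM in this assay, at which 3 of the 4 values shown sit.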